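The compounds below may be only part of what the source reports. "The series", "measured", "known", "first", "only" and "open" are said of these compounds alone.

Compound 1 `CCNC(=O)c1nc(-c2cc(OC)c(OC)c(OC)c2)n(-c2ccc(OC)cc2)n1`: 60%
Compound 2 `COc1ccc(-n2nc(C(=O)Nc3ccc(C(F)(F)F)cc3)nc2-c2cc(OC)c(OC)c(OC)c2)cc1`: 48%

Both were tested in a functional assay on the whole organism for inhibition, with Rattus norvegicus as the target, read by paw edema, with stated times of 30 min and 1 h, at a dose of 0.28 mmol/kg by the oral route; a lower number here means less inhibition, a higher number more inhibition at the dose given (going by the name of the read-out). For the measured compounds named here, compound 1 stands highest of the two measured numbers; the only other number lies lower, and that step, a number 12 percentage points lower from compound 1 to compound 2 (beyond the scatter), is beyond the scatter. Compound 3 `COc1ccc(-n2nc(C(=O)Nc3ccc(C(=O)O)cc3)nc2-c2cc(OC)c(OC)c(OC)c2)cc1` has not yet been measured. It differs from compound 1 in one place: 4-carboxyphenyl in place of ethyl on an amide-type nitrogen. Going by the values given here, the one measured step that bears on this is the exchange of ethyl for a substituted phenyl on the same amide-type nitrogen, which gave a number 12 percentage points lower from compound 1 to compound 2 (beyond the scatter). Because that earlier exchange gave a number 12 percentage points lower from compound 1 to compound 2 (beyond the scatter), a drop of similar size is expected for compound 3, a number 12 percentage points lower from compound 1 to compound 3 (beyond the scatter), although the carboxyl group differs from trifluoromethyl and nothing measured shows how much that matters. Compound 3 is therefore estimated at 48%, within a range from 32% to 62%.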

Compound 3, a percentage reported as inhibition, in the whole organism at one dose (the size of the read-out at that dose, not a potency): 50%
The estimate for compound 3 lay 2 percentage points below the measured number, within the range that was stated.
By their numbers in this assay, from the lowest: compounds 2, 3 and 1 (each within the scatter of the next, the first and the last beyond it).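

With the carboxy group on the added ring, replacing ethyl on the amide-type nitrogen gives in this assay a number 10 percentage points lower from compound 1 to compound 3 (within the scatter), so a substituted phenyl at this position does not always take the number beyond the scatter, as the trifluoromethyl compound did. On the aromatic carbon, the change from trifluoromethyl to carboxy gives a number 2 percentage points higher from compound 2 to compound 3 (within the scatter), so this assay does not separate these two groups at this dose. Nothing measured here explains why these numbers fall as they do.

Still open, from the compounds shown here alone, is how an unsubstituted phenyl ring or a longer chain such as butyl would compare with ethyl on this nitrogen. An amine or a methoxy group in place of carboxy on the aromatic carbon would show whether other groups there also stay within the scatter.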